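The compounds below may be only part of what the source reports. "The series", "measured", "known", "first", "only" and "open" are said of these compounds alone.

Compound 1 `CC1=C(C(=O)Nc2ccc(F)cc2)C(c2ccc([N+](=O)[O-])cc2)N=C(SCc2ccccc2Cl)N1` and compound 2 `CC1=C(C(=O)Nc2ccc(F)cc2)C(c2ccc([N+](=O)[O-])cc2)N=C(SCc2cccc(Cl)c2)N1` share a core and differ in one place only. In a functional assay on the whole organism (artery, strain albino) with Rattus norvegicus as the target, with a stated time of 600 min, at a dose of 10 mg/kg by the oral route (a higher number here means more inhibition at the dose given (going by the name of the read-out), a lower number less inhibition), compound 1 gives 17.4%, and in the same assay compound 2 gives 16.4%. The change between them is 3-chlorophenyl in place of 2-chlorophenyl on a saturated chain carbon bound to a sulfur, and the step it made, a number 1 percentage points lower from compound 1 to compound 2 (within the scatter), lies within the scatter of the measurement.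

Compound 3 `CC1=C(C(=O)Nc2ccc(Br)cc2)C(c2ccc(Cl)cc2Cl)N=C(SCc2ccccc2Cl)N1` carries a different core; how its core differs from that of compound 1 is not broken down here. In this assay compound 3 gives 24.6%. This is the highest of the three numbers, but its distance from compound 1 and from compound 2 is within the scatter, so no order among the three can be claimed.

Compound 4 `CC1=C(C(=O)Nc2ccc(Br)cc2)C(c2ccc(Cl)cc2Cl)N=C(SCc2cccc(Cl)c2)N1` has not yet been measured. It stands to compound 3 as compound 2 stands to compound 1: the difference is 3-chlorophenyl in place of 2-chlorophenyl on a saturated chain carbon bound to a sulfur, the same change made at the same place on the saturated chain carbon bound to a sulfur. Since the earlier step of a number 1 percentage points lower from compound 1 to compound 2 (within the scatter) was within the scatter, the step from compound 3 to compound 4 is expected to be small as well, estimated at a number 1 percentage points lower from compound 3 to compound 4 (within the scatter). On that basis compound 4 is estimated to give 23.6% in this assay, with a likely range from 13% to 34%. The expectation rests on a single earlier pair, compound 1 and compound 2, and on a different core, so the measurement itself must decide.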

Compound 4, a percentage reported as inhibition, in the whole organism at one dose (the size of the read-out at that dose, not a potency): 15.4%
Compound 4: middle estimate off by 8.2 percentage points, on the high side, within the range that was stated.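

On the core of compound 3, placing 3-chlorophenyl where 2-chlorophenyl stood on a saturated chain carbon bound to a sulfur gives, in this assay, a number 9.2 percentage points lower from compound 3 to compound 4 (within the scatter). Among the compounds shown here, this shows that, on both cores, the change produces no step that can be told from the scatter, so these four compounds offer no sign that its outcome depends on the core. It does not show that the change is without effect or that the two cores respond alike, as each core contributes a single pair at one dose and one time, and steps of such different printed size may still hide a real difference. The two steps compare as follows: the same change on two cores in this assay, a number 1 percentage points lower (within the scatter) from compound 1 to compound 2 and a number 9.2 percentage points lower (within the scatter) from compound 3 to compound 4, 8.2 percentage points apart, within the scatter of two such steps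

The compounds shown leave open whether the same holds on the saturated chain carbon bound to a sulfur for groups other than the two chlorophenyl rings, such as an unsubstituted phenyl, a longer chain, an amine or a carboxylic acid. They also leave open whether the change would give a clearer step on a third core, or whether any group at this place moves the inhibition beyond the scatter in this assay at all.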